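Swapping a Piperazine for a Small Sulfur Group

The compounds below may be only part of what the source reports. "The series", "measured", "known", "first", "only" and "open" are said of these compounds alone.

Of the compounds shown here, two have so far been tested in a functional assay on HEK293 cells for antagonist activity at 5-hydroxytryptamine receptor 6 (Homo sapiens), read by cAMP accumulation, with a stated time of 2 h; on this read-out higher numbers stand for weaker inhibition and lower numbers for stronger inhibition. Compound 1 `Cc1cc(C)n2nc(C)c(S(=O)(=O)c3ccccc3)c2n1` gives 88.8 nM in this assay. Compound 2 `Cc1cc(C)n2nc(N3CCNCC3)c(S(=O)(=O)c3ccccc3)c2n1`, which carries a piperazin-1-yl in place of the methyl on an aromatic carbon, gives 1380 nM in this assay. Among the measured compounds shown here, of the two numbers, compound 2 stands highest, meaning the weakest inhibition of the pair, and the step of a 16-fold higher number from compound 1 to compound 2 (1.19 log units; beyond the scatter) is the only measured step available. The new compound, compound 3 `Cc1cc(C)n2nc([S+](C)[O-])c(S(=O)(=O)c3ccccc3)c2n1`, differs from compound 2 by a group of 3 heavy atoms (1 carbon, 1 oxygen, 1 sulfur; no ring) in place of a group of 6 heavy atoms (4 carbon, 2 nitrogen; one six-membered non-aromatic ring with 2 hetero atoms), on an aromatic carbon. The measured step bears on this change only indirectly: it shows that the piperazin-1-yl at this aromatic carbon weakens inhibition markedly compared with a methyl, whereas compound 3 carries a group without a ring and without a hydrogen-bond donor, nearer in kind to the methyl of compound 1. The number for compound 3 is therefore expected to fall between the two measured values, as the step of a 6.9-fold lower number from compound 2 to compound 3 (0.84 log units; beyond the scatter) toward stronger inhibition. The estimate for compound 3 in this assay is 200 nM, with a range from 40 nM to 1000 nM.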

Compound 3, inhibition constant: 2960 nM
Compound 3: the middle estimate sits 15-fold (1.17 log units) below what was measured; measured number outside the range, above it.
By their numbers in this assay, from the lowest: compound 1; then compound 2; then compound 3.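

In this assay the group of 3 heavy atoms, with no ring and 0 hydrogen-bond donors, gives a 2.1-fold higher number from compound 2 to compound 3 (0.33 log units; beyond the scatter) as a modest step, so losing the ring and the donor of piperazin-1-yl does not bring the number back toward that of the methyl compound. Set against the methyl directly, the same group gives a 33-fold higher number from compound 1 to compound 3 (1.52 log units; beyond the scatter) as a large step, which shows that a small group at this aromatic carbon does not by itself go with a low number, and that of the three groups seen here the methyl gives the strongest inhibition. No measurement at hand explains these differences.

Among the compounds shown here, with only three groups at this aromatic carbon, it remains open how much depends on the oxygen on the sulfur, which a plain methylthio group, with sulfur alone, or a methylsulfonyl group, with two oxygens, could begin to separate. Going by these compounds, it is also open whether a simple amine or a longer carbon chain such as ethyl would stay close to compound 1 or move toward the weaker numbers of compound 2 and compound 3.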